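The source may hold more compounds than are shown below. What is called first, only, known or untested is meant among the compounds shown, and "the series" means these compounds.

Working notes on the series. Compound 1 `Cc1cc(OCc2ccccc2)c2nc(C)c(C)n2c1` stands lowest of the two numbers in hand: in a functional assay on the whole organism with Canis familiaris (Canis lupus familiaris) as the target, at a dose of 8 mg/kg by the oral route (a lower number here means a weaker effect, a higher number a stronger effect of the compound at the dose given), compound 1 gives 71%, while compound 2 `Cc1nc2c(OCc3ccc(F)cc3)cccn2c1N` in this assay gives 93%, a gap beyond the usual scatter. Compound 3 `Cc1cc(OCc2ccccc2)c2nc(C)c(N)n2c1` is not yet measured in this assay; it differs from compound 1 by amino in place of methyl on an aromatic carbon. Among the compounds with values here, no step between measured compounds covers this change, so the expectation rests on the two values alone. An upward step is expected, a number 14 percentage points higher from compound 1 to compound 3 (beyond the scatter), since compound 2, which also carries an amino group on its core, reaches 93%. Compound 3 is therefore estimated at 85%, in the range 70% to 97%.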

Compound 3, a percentage reported as inhibition, in the whole organism at one dose (the size of the read-out at that dose, not a potency): 50%
For compound 3 the middle estimate is 35 percentage points above the measured one, and the stated range ends above it.
By their numbers in this assay, from the lowest: compound 3; then compound 1; then compound 2.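

In this assay amino in place of methyl on this aromatic carbon of the five-membered ring gives a number 21 percentage points lower from compound 1 to compound 3 (beyond the scatter) and so, at this position, methyl holds up better than amino. Within the data shown here, this is the first step read at this position, and compound 2 differs from compound 3 in more than one place, so it does not bear on this change. Nothing in hand explains the drop.

Still open, from the compounds shown here alone, is whether ethyl or hydroxyl at this position would stay nearer compound 1 or compound 3. Also open, going by these compounds, is how methyl in place of amino would read on the core of compound 2.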